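Methyl-to-hydrogen change on the core of compound 3

A few compounds are considered here, and "the series" means these few. Any claim that something is new, unique, unknown or untested is made for them only; others in the source may bear on it.

Compound 3 `Cc1c(O[C@H]2CC[C@]3(CC2)COC(C)(C)C3)ncnc1N1CCc2cc(S(C)(=O)=O)ccc21` stands lowest of the three intrinsic activity values recorded in a functional assay on HEK293 cells with Glucose-dependent insulinotropic receptor (Homo sapiens) as the target, read by HTRF and cAMP accumulation, with a stated time of 30 min (a higher number here means a larger maximal response, a lower number a smaller maximal response), where compound 3 gives 38%. The nearest value belongs to compound 1 `Cc1c(Oc2ccc(S(C)(=O)=O)cc2F)ncnc1O[C@H]1CC[C@]2(CC1)COC(C)(C)C2`, which in this assay gives 62%, a gap beyond the scatter. The furthest belongs to compound 2 `CC1(C)C[C@]2(CC[C@H](Oc3ncnc4c3CCN4c3ccc(S(C)(=O)=O)cc3F)CC2)CO1`, which in this assay gives 90%, also beyond the scatter.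

Compound 4 `CC1(C)C[C@]2(CC[C@H](Oc3cc(N4CCc5cc(S(C)(=O)=O)ccc54)ncn3)CC2)CO1` has not yet been measured. It differs from compound 3 in one place: hydrogen in place of methyl on an aromatic carbon. Going by the values given here, no measured pair shows this change by itself; compound 1, compound 2 and compound 3 differ from one another in the core and the attached aryl group, so the size of a methyl-to-hydrogen swap cannot be read from them. The expectation is a small step, with no strong lean in either direction and possibly none beyond the scatter. The expected step is a number 7 percentage points higher from compound 3 to compound 4 (within the scatter). Compound 4 is estimated to give 45% in this assay, within a range from 25% to 70%.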

Compound 4, intrinsic activity: the largest response reached, in percent of the reference agonist's in the Glucose-dependent insulinotropic receptor assay: 87%
The estimate for compound 4 lay 42 percentage points below the measured number; measured number outside the range, above it.
By their numbers in the Glucose-dependent insulinotropic receptor assay, from the lowest: compound 3; then compound 1; then compounds 4 and 2 (each within the scatter of the next).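

In the Glucose-dependent insulinotropic receptor assay hydrogen in place of methyl on this aromatic carbon, ortho to two large groups, gives a number 49 percentage points higher from compound 3 to compound 4 (beyond the scatter) and so shows that this position is far from silent for maximal response, although only one carbon leaves and no ring, donor, acceptor or charge is involved. In a physicochemical assay for solubility, in simulated intestinal fluid (on this read-out higher numbers stand for higher solubility and lower numbers for lower solubility), compound 3 gives 25500 nM and compound 4 gives 19800 nM and the same change gives a 1.3-fold lower number from compound 3 to compound 4 (0.11 log units; within the scatter) so on this pair the large step appears in only one of the two read-outs.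

From the compounds shown here alone, whether the step is specific to methyl remains open, since an ethyl, a chlorine or a methoxy on this carbon would be needed to tell, as does whether it carries over to the cores of compound 1 and compound 2. No measurement at hand explains the size of the step.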